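The compounds below may be only part of what the source reports. "The series", "measured", "known", "first", "only" and "open" are said of these compounds alone.

Measured so far:
compound 1 `Cn1ncc(Cl)c1-c1cc(C(=O)N[C@@H]2CN[C@H](CCNS(C)(=O)=O)C[C@H]2c2ccc(F)c(F)c2)oc1Cl`: 3.29 nM
compound 2 `Cn1ncc(Cl)c1-c1cc(C(=O)NC2CNCC2c2ccc(C(F)(F)F)cc2)oc1Cl`: 538 nM
compound 3 `Cn1ncc(Cl)c1-c1cc(C(=O)N[C@@H]2CN[C@H](CC(N)=O)C[C@H]2c2ccc(Cl)c(Cl)c2)oc1Cl`: 3.24 nM

In an assay for inhibition of RAC-alpha serine/threonine-protein kinase (Homo sapiens), read by HTRF, with a stated time of 1 h (a lower number here means a stronger inhibitor, a higher number a weaker inhibitor), compound 3 gives the lowest number of the three, but compound 1 lies within the scatter of it, so the two cannot be ordered; compound 2 sits far higher than both. Compound 4 `COCC[C@@H]1C[C@@H](c2ccc(Cl)c(Cl)c2)[C@H](NC(=O)c2cc(-c3c(Cl)cnn3C)c(Cl)o2)CN1` has not been measured. The change from compound 3 is methoxymethyl in place of carbamoyl on a saturated chain carbon bound to a saturated ring carbon. For the measured compounds named here, no measured pair isolates this change. Compound 1 and compound 3 agree within the scatter, which gives no sign that this region is sensitive. For compound 4 the step is expected to be small, a 1.9-fold higher number from compound 3 to compound 4 (0.27 log units; within the scatter), leaning toward a somewhat higher number. Compound 4 is estimated at 6 nM, in a range from 2 nM to 20 nM.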

Compound 4, half-maximal inhibitory concentration: 7.01 nM
The estimate for compound 4 lay 1.2-fold (0.07 log units) below the measured number; the range from low to high includes it.
By their numbers in this assay, from the lowest: compounds 3 and 1 (each within the scatter of the next); then compound 4; then compound 2.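

In this assay, for the compounds shown here, methoxymethyl in place of carbamoyl on a saturated chain carbon bound to a saturated ring carbon gives a 2.2-fold higher number from compound 3 to compound 4 (0.34 log units; beyond the scatter), the first single-change reading at this position. The position therefore registers this change, but only modestly, even though the entering group counts no hydrogen-bond donor and the leaving group counts one. No measurement here accounts for the step.

Going by these compounds, whether the donor count matters remains open, as this single pair also changes the atoms present. A primary amine, a carboxylic acid or a longer chain at this place would show how far the position tolerates change.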